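A few compounds are considered here, and "the series" means these few. Any claim that something is new, unique, unknown or untested is made for them only; others in the source may bear on it.

In a physicochemical assay for solubility, in phosphate buffer, with a stated time of 24 h, at pH 7.4, tested at 200 uM (on this read-out lower numbers stand for lower solubility and higher numbers for higher solubility), compound 1 `O=C(c1ccc(F)c(O)c1)c1ccc2cc(O)ccc2n1` gives > 200000 nM, which is a limit of the assay and not a number. Compound 2 `C=C(c1ccc(F)c(O)c1)c1cccc(-c2cccc(O)c2F)n1` gives > 200000 nM, which is also a limit. Neither compound therefore supplies an exact figure, and the picture so far is the limit of > 200000 nM in this assay, at which 2 of the 2 values shown sit. Compound 3 `Cc1ccc2nc(C(=O)c3ccc(F)c(O)c3)ccc2c1` departs from compound 1 in one place, with methyl in place of hydroxy on an aromatic carbon, part of a fused or bridged system of two rings: methyl in place of hydroxy on an aromatic carbon. Going by the values given here, no measured step between these compounds is available to guide the size of this change, so the expectation remains tentative. In this assay a moderate downward step beyond the usual scatter is expected, estimated as an at least 2.2-fold lower number from compound 1 to compound 3 (0.34 log units; beyond the scatter). Compound 3 is expected to read 90000 nM, with an estimated range of 25000 nM to 200000 nM.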

Compound 3, solubility: 25000 nM
The estimate for compound 3 lay 3.6-fold (0.56 log units) above the measured number; the measured number falls inside the stated range.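

In this assay, methyl in place of hydroxy on an aromatic carbon, at this place on the shared core, gives an at least 8.0-fold lower number from compound 1 to compound 3 (0.90 log units; beyond the scatter). Compound 1 gives > 200000 nM, which is a limit of the assay. Compound 3 is the first compound shown with an exact figure, so this change is the only single change here that gives a readable step, and the other values remain at the limit: the limit of > 200000 nM in this assay, at which 2 of the 3 values shown sit.

The compounds shown leave open whether another group at this position, such as an amine, a methoxy group or a carboxylic acid, would read closer to compound 3 or stay at the limit of compound 1. They also leave open whether the same change made elsewhere on the shared core would give a step of similar size.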